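Taking one chloro from compound 3

A few compounds are considered here, and "the series" means these few. Any claim that something is new, unique, unknown or untested is made for them only; others in the source may bear on it.

In a functional assay on KB cells (Homo sapiens) for inhibition (on this read-out lower numbers stand for stronger inhibition and higher numbers for weaker inhibition), compound 1 `Nc1nc2cc(Cl)c(Cl)cc2n1Cc1cccc(Cl)c1` gives a measured value of 65000 nM. Compound 2 `Clc1cc2nc(Br)n(Cc3ccccc3)c2cc1Cl` gives no number, only a limit of the assay, > 100000 nM. Compound 3 `Clc1ccc(Cn2c(Br)nc3cc(Cl)c(Cl)cc32)cc1Cl` likewise gives only a limit, > 100000 nM. Compound 3 therefore stands at the limit of > 100000 nM in this assay, at which 2 of the 3 values shown sit, and its true value is not known.

Compound 4 `Clc1cccc(Cn2c(Br)nc3cc(Cl)c(Cl)cc32)c1` follows from compound 3 with one change: hydrogen in place of chloro on an aromatic carbon, ortho to a chloro group and para to a large group (hydrogen in place of chloro on an aromatic carbon). For the measured compounds named here, no measured pair in this small set shows the size of such a change, so the expectation rests on compound 3 alone. No shift beyond the scatter is expected in this assay, and the estimated step is a number no higher from compound 3 to compound 4 (the limit leaves the size open). The assay may well report only a limit again. Compound 4 is expected at about 100000 nM, with an estimated range from 40000 nM to 250000 nM.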

Compound 4, half-maximal inhibitory concentration: > 100000 nM
Compound 4 gave a limit, no number; the forecaster's own chance of this, stated with the estimate: 75%; the middle value lies on the limit itself.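

In this assay compound 4 gives only a limit, > 100000 nM, so taking away the chloro that stood para to a large group brings no number into view, and the steps reaching it from the other two bromo compounds cannot be read. For the compounds shown here, the one readable comparison concerns a different place: bromo in place of amino on an aromatic carbon gives an at least 1.5-fold higher number from compound 1 to compound 4 (0.18 log units; that floor lies within the scatter), and this pair sets that change on its own for the first time, though its floor stays within the scatter. Compound 4 joins compound 2 and compound 3 at the same ceiling of the assay: the limit of > 100000 nM in this assay, at which 3 of the 4 values shown sit.

Going by these compounds, how far compound 4 lies past its limit remains unknown, so the effect of the chloro cannot be sized. Whether a methylamino group or a carboxylic acid in place of the bromo would give a measurable value is also left open.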